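Sulfonamide Aryl Variation on a Weakly Active Shared Core

This account rests on a few compounds, and the source may have more. Where it says the series, first, only, none or still open, it means among the compounds named here.

Compound 1 `CN(c1ccccc1)S(=O)(=O)C1CC2OC1C(c1ccc(NC(=O)CCCCCCC(=O)O)cc1)=C2c1ccc(O)cc1`: in a functional assay on DU-145 cells (Homo sapiens) for antiproliferative activity, read by MTT assay, with a stated time of 72 h (a lower number here means a stronger inhibitor, a higher number a weaker inhibitor), compound 1 gives > 100000 nM, which is a limit of the assay.
Compound 2 `Cc1cccc(N(C)S(=O)(=O)C2CC3OC2C(c2ccc(NC(=O)CCCCCCC(=O)O)cc2)=C3c2ccc(O)cc2)c1`: in this assay compound 2 gives > 100000 nM, which is a limit of the assay.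
Compound 3 `CN(c1ccc(Cl)cc1)S(=O)(=O)C1CC2OC1C(c1ccc(NC(=O)CCCCCCC(=O)O)cc1)=C2c1ccc(O)cc1`: in this assay compound 3 gives 72100 nM.

Compound 2 therefore stands at the limit of this assay, and it shares that position with one other compound (the limit of > 100000 nM in this assay, at which 2 of the 3 values shown sit). Only compound 3 gives a number, and the step of an at least 1.3-fold lower number from compound 2 to compound 3 (0.14 log units; that floor lies within the scatter) shows that a 4-chlorophenyl in place of a 3-methylphenyl on the sulfonamide nitrogen moves the value just off the limit. The step that the two limits leave unreadable from compound 1 to compound 2 cannot be read, since both ends sit at the limit.

Compound 4 `CCN(c1ccc(OC)cc1)S(=O)(=O)C1CC2OC1C(c1ccc(NC(=O)CCCCCCC(=O)O)cc1)=C2c1ccc(O)cc1` is not yet measured. It differs from compound 2 by ethyl(4-methoxyphenyl)amino in place of methyl(3-methylphenyl)amino on a sulfonyl sulfur. This is again a change of the aryl and alkyl groups on the sulfonamide, the same region varied in the step from compound 2 to compound 3, and that step was small. With all three measured compounds weak and two at the limit, compound 4 is expected to remain weak, with the step of a number no higher from compound 2 to compound 4 (the limit leaves the size open) expected to be small or none beyond the scatter. For compound 4 the estimate in this assay is 100000 nM, with a range from 40000 nM to 300000 nM.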

Compound 4, half-maximal inhibitory concentration: 24400 nM
Compound 4: middle estimate off by 4.1-fold (0.61 log units), on the high side, and the stated range ends above it.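

Going by these compounds alone, the sulfonamide position, where the earlier compounds barely left the limit, does respond to change: in this assay, ethyl(4-methoxyphenyl)amino on the sulfonyl sulfur gives a 3.0-fold lower number from compound 3 to compound 4 (0.47 log units; beyond the scatter), the first step at this place that is a full measured difference beyond the scatter. The other two comparisons point the same way, with an at least 4.0-fold lower number from compound 2 to compound 4 (0.61 log units; beyond the scatter) and an at least 4.0-fold lower number from compound 1 to compound 4 (0.61 log units; beyond the scatter), so compound 4 is the strongest of the four shown, although its number remains high for this series of weak compounds. These last two steps are floors and not sizes, and the real gaps may be larger, since compound 1 and compound 2 remain at a limit of the assay: the limit of > 100000 nM in this assay, at which 2 of the 4 values shown sit.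

What the compounds shown leave open is which part of the change carries the step, since ethyl on the nitrogen and 4-methoxy on the aryl ring enter together and no compound shown has one without the other. On these data alone, it also stays open whether a propyl group on the sulfonamide nitrogen or a 4-ethoxyphenyl group on it would lower the number further.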